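Shifting the nitro group on the shared core

The source may report more compounds than this note shows. Statements on the series, on what has been measured and on what is new or still open speak of the compounds shown alone.

Compound 1, `COc1ccc(Cl)cc1C(=O)Nc1ccc(C2=NN(c3ccccc3)C(c3ccccc3[N+](=O)[O-])C2)cc1`, gives 88.4% in a functional assay on the whole organism (strain albino) with Rattus norvegicus as the target, read by paw edema, with stated times of 1 h and 4 h, at a dose of 50 mg/kg by the oral route; on this read-out lower numbers stand for a weaker effect and higher numbers for a stronger effect at the one dose given.
Compound 2, `COc1ccc(Cl)cc1C(=O)Nc1ccc(C2=NN(c3ccccc3)C(c3ccc([N+](=O)[O-])cc3)C2)cc1`, gives 94.1% in this assay.
Compound 3, `COc1ccc(Cl)cc1C(=O)Nc1ccc(C2=NNC(c3ccccc3[N+](=O)[O-])C2)cc1`, gives 90.9% in this assay.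

All three measured compounds share a core and differ only at its edge. Compound 2 arises from compound 1 by 4-nitrophenyl in place of 2-nitrophenyl on a saturated ring carbon, and this change made a step of a number 5.7 percentage points higher from compound 1 to compound 2 (within the scatter). Compound 3 arises from compound 1 by hydrogen in place of phenyl on an amine nitrogen in a ring, with a step of a number 2.5 percentage points higher from compound 1 to compound 3 (within the scatter). Compound 4, `COc1ccc(Cl)cc1C(=O)Nc1ccc(C2=NNC(c3ccc([N+](=O)[O-])cc3)C2)cc1`, is not yet measured; it differs from compound 3 by 4-nitrophenyl in place of 2-nitrophenyl on a saturated ring carbon. Within the data shown here, this is the same kind of change as the one from compound 1 to compound 2, yet not the same: in the pair of compound 1 and compound 2 the place is also next to the ring atom that bears a phenyl group, whereas in compound 3 and compound 4 that ring nitrogen carries hydrogen. Compound 4 is expected to show a step of a number 3.1 percentage points higher from compound 3 to compound 4 (within the scatter), resting on the small step of a number 5.7 percentage points higher from compound 1 to compound 2 (within the scatter) seen for the same kind of change. Compound 4 is therefore estimated at 94%, likely between 86% and 99%.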

Compound 4, a percentage reported as activity, at one dose (the size of the read-out at that dose, not a potency): 95.3%
The estimate for compound 4 lay 1.3 percentage points below the measured number; low and high end bracket the measured number.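

In this assay, 4-nitrophenyl in place of 2-nitrophenyl on the saturated ring carbon, on the core with hydrogen on the ring nitrogen, makes a step of a number 4.4 percentage points higher from compound 3 to compound 4 (within the scatter): the same change on two cores in this assay, a number 5.7 percentage points higher (within the scatter) from compound 1 to compound 2 and a number 4.4 percentage points higher (within the scatter) from compound 3 to compound 4, 1.3 percentage points apart, within the scatter of two such steps. Hydrogen in place of phenyl on the ring nitrogen, on the core carrying 4-nitrophenyl, makes a step of a number 1.2 percentage points higher from compound 2 to compound 4 (within the scatter): the same change on two cores in this assay, a number 2.5 percentage points higher (within the scatter) from compound 1 to compound 3 and a number 1.2 percentage points higher (within the scatter) from compound 2 to compound 4, 1.3 percentage points apart, within the scatter of two such steps. Among these compounds, each change therefore looks alike on both cores, but every step is within the scatter, so this shows only that neither change made a clear difference on either core, not that either change truly raises the number.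

The compounds shown carry only a nitro group on that aromatic ring and only phenyl or hydrogen on the ring nitrogen, so it stays open whether the same agreement would hold for an amine or a carboxylic acid in place of the nitro group, or for a longer chain on the ring nitrogen. A read-out at one dose also tells only how strong the effect of all four compounds is at that dose.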